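This account rests on a few compounds, and the source may have more. Where it says the series, first, only, none or still open, it means among the compounds named here.

Compound 2 `Nc1nc2cc(-c3nn(CCCCCC(=O)NO)c4ncnc(N)c34)ccc2o1` gives 2030 nM in a functional assay on Bel-7402 cells (Homo sapiens) for inhibition, read by MTT assay, with a stated time of 72 h (a lower number here means a stronger inhibitor, a higher number a weaker inhibitor), the lowest of the two numbers shown. Compound 1 `CNC(=O)CCCCCCCn1nc(-c2ccc3oc(N)nc3c2)c2c(N)ncnc21` gives 13200 nM in this assay, and the step of a 6.5-fold lower number from compound 1 to compound 2 (0.81 log units; beyond the scatter) accompanies hydroxycarbamoyl in place of 2-(methylcarbamoyl)ethyl. Compound 3 `Nc1nc2cc(-c3nn(CCCCCCCCCC(=O)NO)c4ncnc(N)c34)ccc2o1` differs from compound 2 only in chain length: 4-(hydroxycarbamoyl)butyl in place of hydroxycarbamoyl on a saturated chain carbon, five bonds along the chain from an aromatic nitrogen. Among the measured compounds shown here, no measured step changes the chain length, so the single step at hand bears on this only loosely. The hydroxycarbamoyl end stays, so compound 3 is expected to shift little, a 1.4-fold lower number from compound 2 to compound 3 (0.13 log units; within the scatter). Compound 3 is estimated at 1500 nM, with a range from 500 nM to 5000 nM.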

Compound 3, half-maximal inhibitory concentration: > 50000 nM
Compound 3 ended at the assay's limit (the forecaster's own chance of this, stated with the estimate: 3%); at least 33-fold (1.52 log units) between middle value and limit.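

Putting 4-(hydroxycarbamoyl)butyl in place of hydroxycarbamoyl at this position is far from neutral in this assay, giving an at least 24-fold higher number from compound 2 to compound 3 (1.39 log units; beyond the scatter). Keeping the hydroxycarbamoyl end therefore does not preserve activity when the chain grows, and the comparison with the methylcarbamoyl compound gives an at least 3.7-fold higher number from compound 1 to compound 3 (0.57 log units; beyond the scatter). Compound 3 stands at a limit of the assay, not at a number: the limit of > 50000 nM in this assay, at which 1 of the 3 values shown sits.

Open, as far as these compounds go, is how a chain of intermediate length or a shorter chain would read. Also open, from the compounds shown here alone, is whether a carboxylic acid in place of the hydroxycarbamoyl end would change the picture.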